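Removing a Methyl from an Aromatic Carbon in Two Cores

The source may hold more compounds than are shown below. What is called first, only, known or untested is meant among the compounds shown, and "the series" means these compounds.

Measured compounds:
Compound 1, `COc1ccc2nc(-c3ccc(N/C=C\C(=O)c4cc(OC)c(OC)c(OC)c4Br)c(C)c3)sc2c1`, gives 9400 nM in a functional assay on MDA-MB-231 cells (Homo sapiens) for antiproliferative activity, read by sulforhodamine B assay, with a stated time of 48 h; on this read-out higher numbers stand for weaker inhibition and lower numbers for stronger inhibition.
Compound 2, `COc1ccc2nc(-c3ccc(N/C=C\C(=O)c4cc(OC)c(OC)c(OC)c4Br)cc3)sc2c1`, gives 11100 nM in this assay.
Compound 3, `COc1cc(C(=O)/C=C\Nc2ccc(-c3nc4cc(OC)c(OC)c(OC)c4s3)cc2C)cc(OC)c1OC`, gives 12900 nM in this assay.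

Compound 1 and compound 2 differ in one place: hydrogen in place of methyl on an aromatic carbon. This change made the step of a 1.2-fold higher number from compound 1 to compound 2 (0.07 log units; within the scatter). Compound 3 carries a different core; the difference between the two cores is not broken down here. Compound 4, `COc1cc(C(=O)/C=C\Nc2ccc(-c3nc4cc(OC)c(OC)c(OC)c4s3)cc2)cc(OC)c1OC`, is still unmeasured and differs from compound 3 by hydrogen in place of methyl on an aromatic carbon. This is the same kind of change as the earlier one, though the surroundings are described differently: in the first pair the carbon is meta to a 6-methoxy-1,3-benzothiazol-2-yl group, in the second it is meta to a large group. Since the earlier step of a 1.2-fold higher number from compound 1 to compound 2 (0.07 log units; within the scatter) stayed within the scatter, compound 4 is expected to show a step of about a 1.2-fold higher number from compound 3 to compound 4 (0.07 log units; within the scatter) in this assay. Compound 4 is therefore estimated at 15000 nM, expected to fall between 6500 nM and 35000 nM.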

Compound 4, half-maximal inhibitory concentration: 16500 nM
Compound 4: middle estimate off by 1.1-fold (0.04 log units), on the low side; the range from low to high includes it.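

Taking the methyl off the aromatic carbon gave a 1.3-fold higher number from compound 3 to compound 4 (0.11 log units; within the scatter) in this assay, so on this second core the swap to hydrogen again made no difference beyond the usual scatter of repeated measurements. Set side by side, the two steps agree: the same change on two cores in this assay, a 1.2-fold higher number (0.07 log units; within the scatter) from compound 1 to compound 2 and a 1.3-fold higher number (0.11 log units; within the scatter) from compound 3 to compound 4, 1.1-fold (0.03 log units) apart, within the scatter of two such steps. Going by these compounds alone, on these two cores, then, the methyl can be removed with no readable effect on this number, but that rests on only two pairs and shows a shared absence of effect, not an effect of measurable size that carries from core to core.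

The compounds shown leave open whether a different group at the same place, such as an amine or a carboxylic acid, would give a step beyond the scatter. They also leave open whether this swap would stay as small on any further core.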